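The source may report more compounds than this note shows. Statements on the series, on what has been measured and on what is new or still open speak of the compounds shown alone.

Compound 1 `CN(C(=O)c1ccccc1OCc1ccccc1)[C@@H]1CCC[C@H](N)C1`, in an assay on HEK293 cells for inhibition of transient receptor potential cation channel subfamily M member 8 (Homo sapiens), read by FLIPR and calcium flux (a higher number here means a weaker inhibitor, a lower number a stronger inhibitor), gives 3150 nM. Compound 2 `CCCN(C(=O)c1ccccc1OCc1ccccc1)[C@@H]1CCC[C@H](N)C1` gives 1230 nM. Compound 3 `CC(C)N(C(=O)c1ccccc1OCc1ccccc1)[C@@H]1CCC[C@H](N)C1` gives 8780 nM.

Compound 2 has the lowest number of the three, and its distance from both other compounds lies beyond the scatter. Compound 4 `CCCCN(C(=O)c1ccccc1OCc1ccccc1)[C@@H]1CCC[C@H](N)C1` differs from compound 2 by methyl in place of hydrogen on a saturated chain carbon, three bonds along the chain from an amide-type nitrogen. The step that bears most on this change is a 2.6-fold lower number from compound 1 to compound 2 (0.41 log units; beyond the scatter), which also lengthened a straight chain on the same nitrogen; the steps of a 2.8-fold higher number from compound 1 to compound 3 (0.45 log units; beyond the scatter) and a 7.1-fold higher number from compound 2 to compound 3 (0.85 log units; beyond the scatter) concern isopropyl and weigh less here. Lengthening has so far lowered the number, while the single branched case raised it, so a further small decrease, or no step beyond the scatter, is expected, the estimated step being a 1.4-fold lower number from compound 2 to compound 4 (0.14 log units; within the scatter). Compound 4 is therefore estimated at 900 nM, within a range from 350 nM to 2500 nM.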

Compound 4, half-maximal inhibitory concentration: 1400 nM
Compound 4: the middle estimate sits 1.6-fold (0.19 log units) below what was measured; the measured number falls inside the stated range.
By their numbers in this assay, from the lowest: compounds 2 and 4 (each within the scatter of the next); then compound 1; then compound 3.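

In this assay, methyl at this carbon, three bonds along the chain from an amide-type nitrogen, gives a 1.1-fold higher number from compound 2 to compound 4 (0.06 log units; within the scatter) and so adds nothing beyond the scatter to the gain seen with the propyl chain. The butyl chain still holds that gain, with a 2.3-fold lower number from compound 1 to compound 4 (0.35 log units; beyond the scatter) on one side and a 6.3-fold lower number from compound 3 to compound 4 (0.80 log units; beyond the scatter) on the other. Nothing available explains why the chain length stops mattering here.

As far as these compounds go, whether a pentyl or longer chain keeps this level remains open. So does the effect of a hydroxyl or an amine at the end of the chain.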